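The compounds below may be only part of what the source reports. "The series", "measured", "known", "first", "only" and "open" are said of these compounds alone.

Measured compounds:
- Compound 1 `COc1ccc(-n2c(S)nnc2-c2cc(OC)c(OC)c(OC)c2)cc1`: in a functional assay on HCT-116 cells (Homo sapiens) for inhibition, read by MTT assay, with a stated time of 48 h (a lower number here means a stronger inhibitor, a higher number a weaker inhibitor), compound 1 gives > 60000 nM, which is a limit of the assay and not a number.
- Compound 2 `COc1ccc(-n2c(SCC(=O)c3ccc(F)cc3)nnc2-c2cc(OC)c(OC)c(OC)c2)cc1`: in this assay compound 2 gives > 60000 nM, again a limit of the assay.
- Compound 3 `COc1cc(-c2nnc(S)n2-c2ccc(N(C)C)cc2)cc(OC)c1OC`: in this assay compound 3 gives > 60000 nM, also a limit of the assay.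

Compound 3 therefore stands only at a limit, with no number of its own, and the same holds for every other compound measured, as the limit of > 60000 nM in this assay, at which 3 of the 3 values shown sit, shows. The step that the two limits leave unreadable from compound 1 to compound 2 cannot be read, and neither can a step that the two limits leave unreadable from compound 1 to compound 3, since both ends sit at the limit.

Compound 4 `CCOC(=O)CSc1nnc(-c2cc(OC)c(OC)c(OC)c2)n1-c1ccc(N(C)C)cc1` is not yet measured. It differs from compound 3 in one place: (ethoxycarbonyl)methyl in place of hydrogen on a sulfur. The closest measured comparison is the change on the sulfur from compound 1 to compound 2, whose size is hidden by the two limits, so no readable step bears on this change. With every shown value at the limit, the expectation is that compound 4 will again fall at or near that limit, the expected step being a step that the limit leaves unreadable from compound 3 to compound 4. Compound 4 is thus estimated at 70000 nM in this assay, within 15000 nM to 300000 nM.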

Compound 4, half-maximal inhibitory concentration: > 60000 nM
Compound 4 ended at the assay's limit (the forecaster's own chance of this, stated with the estimate: 75%); the middle value is on the limit's open side.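

Within the data shown here, compound 3 and compound 4 both sit at a limit of this assay, so placing (ethoxycarbonyl)methyl on the sulfur gives no step that can be read. The compounds shown leave open how strongly any of them inhibits, since none has a number of its own: the limit of > 60000 nM in this assay, at which 4 of the 4 values shown sit.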